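Compound 3 to compound 4: replacing the methoxy group

This account rests on a few compounds, and the source may have more. Where it says the series, first, only, none or still open, it means among the compounds named here.

In an ADME assay on KB cells (Homo sapiens) for cytotoxicity, with a stated time of 48 h (on this read-out lower numbers stand for stronger inhibition and higher numbers for weaker inhibition), compound 3 `COC1=CC(=O)C(O)=C(C/C=C(\C)CC[C@@]2(C)CCC=C(C)[C@H]2C)C1=O` gives > 10 ug/mL as a limit and not a number. In this assay compound 1 `CC1=CCC[C@](C)(CC/C(C)=C/CC2=C(O)C(=O)C=C(N[C@@H](C(=O)O)[C@@H](C)O)C2=O)[C@@H]1C` gives > 10 ug/mL as a limit. In this assay compound 2 `CC1=CCC[C@](C)(CC/C(C)=C/CC2=C(O)C(=O)C=C(N[C@@H](CO)C(=O)O)C2=O)[C@@H]1C` gives > 10 ug/mL as a limit too. Compound 3 therefore stands with its neighbours at the limit of > 10 ug/mL in this assay, at which 3 of the 3 values shown sit, and has no readable rank among them.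

Going to compound 4 `CC1=CCC[C@](C)(CC/C(C)=C/CC2=C(O)C(=O)C=C(NCC(=O)O)C2=O)[C@@H]1C` puts (carboxymethyl)amino in place of methoxy on a double-bonded ring carbon and leaves the rest of the core unchanged.

The measured steps that bear on this change involve the same ring carbon and run in the opposite sense, from a carboxy-bearing amino group to methoxy. These are a step that the two limits leave unreadable from compound 1 to compound 3 and a step that the two limits leave unreadable from compound 2 to compound 3 and neither has a size that can be read. The step that the two limits leave unreadable from compound 1 to compound 2 alters only the amino side chain and is equally unreadable. No direction can be taken from any of them, so no step beyond the scatter is expected in this assay on this evidence. The estimated step is a step that the limit leaves unreadable from compound 3 to compound 4 and it is expected to remain small. For compound 4 the estimate is 15 ug/mL with an expected range from 8 ug/mL to 30 ug/mL and another limit is the likeliest report.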

Compound 4, half-maximal inhibitory concentration: 5.4 ug/mL
Compound 4: the middle estimate sits 2.8-fold (0.44 log units) above what was measured; the whole stated range lies above it.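

In this assay, going by these compounds alone, compound 4 gives 5.4 ug/mL, the first number in the set rather than a limit, and the change at this double-bonded ring carbon, (carboxymethyl)amino in place of methoxy, reads as an at least 1.8-fold lower number from compound 3 to compound 4 (0.26 log units; that floor lies within the scatter). Within the amino side chain, hydrogen in place of hydroxymethyl reads as an at least 1.8-fold lower number from compound 2 to compound 4 (0.26 log units; that floor lies within the scatter) and hydrogen in place of 1-hydroxyethyl reads as an at least 1.8-fold lower number from compound 1 to compound 4 (0.26 log units; that floor lies within the scatter), so the unbranched side chain is the only one of the three that gives a number, although each of these floors stays within the scatter and no real gap is established. The steps among compound 1, compound 2 and compound 3 cannot be read, all three being held at a limit: the limit of > 10 ug/mL in this assay, at which 3 of the 4 values shown sit.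

Open, on these data alone, is whether the free carboxylic acid matters at this position, a question that a methyl ester, a primary amide or a plain alkylamine on the same ring carbon would address. Also open, as far as these compounds go, is how the number responds to a longer chain, such as (2-carboxyethyl)amino, in place of (carboxymethyl)amino on the shared core.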